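Restoring a Carboxy Group: Expected Change in Exposure

This account rests on a few compounds, and the source may have more. Where it says the series, first, only, none or still open, it means among the compounds named here.

Two compounds have so far been run in an ADME assay on the whole organism (Macaca fascicularis) for pharmacokinetics, read by LC-MS, using cassette dosing, at a dose of 1 mg/kg by the oral route; a lower number here means less compound in the circulation, a higher number more compound in the circulation at the dose given. Compound 1 `C[C@H](c1ccc(-c2cc(Cl)ccc2-c2nc(=O)o[nH]2)cc1)N(CC1CC1)c1nc2c(C(=O)O)cccc2o1` gives 976 nM there, and compound 2 `CCCCN(c1nc2ccccc2o1)[C@H](C)c1ccc(-c2ccccc2-c2nnn[nH]2)cc1` gives 29.2 nM. Within the data shown here, compound 2 thus stands lowest of the two numbers, and its only neighbour, compound 1, lies above it by a gap well beyond the usual scatter. Compound 1 and compound 2 differ in several places at once, so no single step can be read from them.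

Compound 3 `CCCCN(c1nc2c(C(=O)O)cccc2o1)[C@H](C)c1ccc(-c2ccccc2-c2nnn[nH]2)cc1` is compound 2 with one change: carboxy in place of hydrogen on an aromatic carbon. Compound 1 carries the same carboxy group on its core and gives 976 nM in this assay, which points to a rise, though the other differences between compound 1 and compound 2 leave the size uncertain. The step is expected to be a 4.1-fold higher number from compound 2 to compound 3 (0.61 log units; beyond the scatter), a modest rise in this assay. Compound 3 is estimated at 120 nM, within a range from 30 nM to 500 nM.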

Compound 3, maximal plasma concentration: 238 nM
Compound 3: the middle estimate sits 2.0-fold (0.30 log units) below what was measured, and the stated range covers the measured number.
By their numbers in this assay, from the lowest: compound 2; then compound 3; then compound 1.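

Among these compounds, this is the first step that isolates a single change. In this assay, carboxy in place of hydrogen on this aromatic carbon gives an 8.2-fold higher number from compound 2 to compound 3 (0.91 log units; beyond the scatter) and so, taken alone, raises the number beyond the scatter with the rest of the structure held constant. The step shows that this position tolerates the added group without any loss in the number, but the data give no account of why the number rises.

As far as these compounds go, it remains open whether a methyl ester, a primary amide or an aminomethyl group at this same position would move the number in the same direction, or whether carboxy would do so on another aromatic carbon of that ring. A single step also cannot show whether the same change gives a similar rise when the butyl chain is replaced by a shorter or branched chain.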